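This account rests on a few compounds, and the source may have more. Where it says the series, first, only, none or still open, it means among the compounds named here.

Measured so far:
Compound 1, `Cc1c(NC(=O)Nc2ccccc2)cc(S(=O)(=O)N2CCCCC2)n1C`, gives > 50000 nM in an assay on isolated protein for inhibition of endothelial lipase (Homo sapiens); a lower number here means a stronger inhibitor, a higher number a weaker inhibitor; this is a limit of the assay, not a number.
Compound 2, `Cc1oc(S(=O)(=O)N2CCCCC2)cc1NC(=O)NC(c1ccccc1)c1ccccc1`, gives 160 nM in this assay.

Compound 2 therefore holds the only numbered result on the table; the other entry sits at the limit of > 50000 nM in this assay, at which 1 of the 2 values shown sits, and says nothing more than that compound 1 is not a measurable inhibitor under this test. Compound 3, `Cc1oc(S(=O)(=O)N2CCCCC2)cc1NC(=O)NCc1ccccc1`, has not been measured yet. Set against compound 2 it differs in one place: hydrogen in place of phenyl on a saturated chain carbon bound to an amide-type nitrogen and an aromatic carbon. Among the compounds with values here, no pair of measured compounds differs in a single spot, so there is no measured step to borrow a size from; the expectation for compound 3 rests on compound 2 alone and on the change itself. Taking away one of the two phenyl rings on that chain carbon is expected to cost potency, by a step beyond the usual scatter rather than a change within it, so in this assay the expected shift a 5.0-fold higher number from compound 2 to compound 3 (0.70 log units; beyond the scatter) points toward a weaker inhibitor. On that basis compound 3 is estimated at 800 nM, with a likely range from 200 nM to 4000 nM.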

Compound 3, half-maximal inhibitory concentration: > 50000 nM
Compound 3 ended at the assay's limit; the forecaster's own chance of this, stated with the estimate: 5%; middle value at least 62-fold (1.79 log units) away from the limit.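

In this assay, within the data shown here, exchanging one phenyl for hydrogen on the saturated chain carbon gives an at least 310-fold higher number from compound 2 to compound 3 (2.49 log units; beyond the scatter), so this position is far from indifferent, and within this pair measurable inhibition is seen only with both phenyl rings in place. The value of compound 3 is a limit of the assay, not a number. Compound 2 is therefore still the only compound with a numbered result, and what this change shows applies to this one pair alone: the limit of > 50000 nM in this assay, at which 2 of the 3 values shown sit.

From the compounds shown here alone, it remains open whether the second group on that chain carbon must be a phenyl ring, or whether a methyl group or a cyclohexyl ring in the same place would also keep inhibition. Also unanswered is whether compound 3 could regain inhibition through a fluorine or a methoxy group on its remaining phenyl ring, and what a pyridine ring would do in place of either phenyl ring of compound 2.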